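The source may hold more compounds than are shown below. What is called first, only, known or untested is meant among the compounds shown, and "the series" means these compounds.

Compound 1 `Cc1ccccc1NS(=O)(=O)c1ccc(N2CCNC2=O)cc1` is one of three close relatives sharing a core carrying a sulfonamide whose nitrogen bears a substituted phenyl. In a functional assay on M21 cells (Homo sapiens) for antiproliferative activity, read by sulforhodamine B assay, with a stated time of 48 h (on this read-out higher numbers stand for weaker inhibition and lower numbers for stronger inhibition), compound 1 gives 150 nM, which places it second highest of the three numbers. Compound 3 `COc1cccc(NS(=O)(=O)c2ccc(N3CCNC3=O)cc2)c1` gives 65 nM, and the single-point change between them, 3-methoxyphenyl in place of 2-methylphenyl on the sulfonamide nitrogen, produced a 2.3-fold lower number from compound 1 to compound 3 (0.36 log units; beyond the scatter). Going by the values given here, compound 2 `O=C1NCCN1c1ccc(S(=O)(=O)Nc2ccc(OC(F)F)cc2)cc1` gives 410 nM, the highest number of the three; no single-point step connects it to compound 1, and its two values simply show that another choice of the phenyl substituent gave a weaker result.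

Compound 4 `O=C1NCCN1c1ccc(S(=O)(=O)Nc2ccc(F)cc2)cc1` differs from compound 1 in one place: 4-fluorophenyl in place of 2-methylphenyl on a sulfonamide nitrogen. Among the compounds with values here, no measured step changes the same pair of groups, so the only guidance is the step from compound 1 to compound 3, which shows that swapping one substituted phenyl for another on this nitrogen moves this assay by a modest amount in either direction. Compound 4 is therefore expected to land near compound 1, with a 1.3-fold higher number from compound 1 to compound 4 (0.12 log units; within the scatter) regarded as the likely outcome, and a number of about 200 nM is estimated for compound 4, within a range from 70 nM to 600 nM.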

Compound 4, half-maximal inhibitory concentration: 230 nM
Estimate against measurement, compound 4: 1.2-fold (0.06 log units) below, and the stated range covers the measured number.
By their numbers in this assay, from the lowest: compound 3; then compounds 1, 4 and 2 (each within the scatter of the next, the first and the last beyond it).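

Exchanging 2-methylphenyl for 4-fluorophenyl on a sulfonamide nitrogen gives a 1.5-fold higher number from compound 1 to compound 4 (0.19 log units; within the scatter) in this assay, so this exchange does not separate the two compounds on this read-out. Compound 4 also gives compound 2 its first single-point link, and fluoro in place of difluoromethoxy on an aromatic carbon gives a 1.8-fold lower number from compound 2 to compound 4 (0.25 log units; within the scatter), which again does not separate the pair. Compound 3 alone has a step to compound 4 that lies beyond the scatter, with 4-fluorophenyl in place of 3-methoxyphenyl giving a 3.5-fold higher number from compound 3 to compound 4 (0.55 log units; beyond the scatter), so among these steps only the 3-methoxyphenyl group stands apart from 4-fluorophenyl. Nothing shown here offers an explanation for how these numbers fall.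

The compounds shown leave open whether the lower number of compound 3 goes with its methoxy group itself or with the place that group occupies on the phenyl ring. They also leave open how this nitrogen would respond to a phenyl ring carrying an amine or a carboxylic acid, or to a longer alkyl chain in place of the phenyl ring.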